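Compound 2 to compound 3: losing the 4-aminocyclohexyl

The source may report more compounds than this note shows. Statements on the series, on what has been measured and on what is new or still open speak of the compounds shown alone.

Values so far in a functional assay on HCT-116 cells (Homo sapiens) for cytotoxicity, read by MTT assay, with a stated time of 72 h (a lower number here means a stronger inhibitor, a higher number a weaker inhibitor), follow
- compound 1 (`CS(=O)(=O)Oc1c(C(=O)NCc2ccc(F)cc2)nc(Br)c2cccnc12`) reads > 20000 nM as a limit
- compound 2 (`N[C@H]1CC[C@H](Nc2c(C(=O)NCc3ccc(F)cc3)nc(Br)c3cccnc23)CC1`) reads 4000 nM as a number

Among the measured compounds shown here, compound 2 at 4000 nM holds the only true number in this assay so far. The entry for compound 1 is a limit. Next comes compound 3 (`O=C(NCc1ccc(F)cc1)c1nc(Br)c2cccnc2c1NCCO`), with the difference 2-hydroxyethyl in place of 4-aminocyclohexyl on a nitrogen on an aromatic ring in view: 2-hydroxyethyl in place of 4-aminocyclohexyl on a nitrogen on an aromatic ring. For the measured compounds named here, the one measured step (an at least 5.0-fold lower number from compound 1 to compound 2 (0.69 log units; beyond the scatter)) brought in the 4-aminocyclohexyl now leaving. On these data alone, its size is bounded only by the limit of > 20000 nM in this assay, at which 1 of the 2 values shown sits, and stays open on one side. Losing that group is therefore expected to move the number upward in this assay by a modest amount beyond the scatter. The estimated step is a 2.5-fold higher number from compound 2 to compound 3 (0.40 log units; beyond the scatter) and no larger is assumed. For compound 3 the estimate is 10000 nM with an expected range from 3500 nM to 28000 nM and a reading at the limit remains possible.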

Compound 3, half-maximal inhibitory concentration: > 20000 nM
Compound 3 was reported as a limit; the forecaster's own chance of this, stated with the estimate: 35%; at least 2.0-fold (0.30 log units) between middle value and limit.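

In this assay, among the compounds shown here, (4-aminocyclohexyl)amino is so far the only group at this place that gives a true number, and the change to (2-hydroxyethyl)amino brings an at least 5.0-fold higher number from compound 2 to compound 3 (0.69 log units; beyond the scatter), so a nitrogen-linked group here does not by itself keep a measurable value. Compound 3 reads > 20000 nM, which is a limit. The step between compound 1 and compound 3 cannot be read, as both entries are limits: the limit of > 20000 nM in this assay, at which 2 of the 3 values shown sit.

On these data alone, whether the ring or the amine of the 4-aminocyclohexyl carries the difference stays open, as compound 3 lacks both. A 2-aminoethyl group or a plain cyclohexyl on this nitrogen would separate the two.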